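Removing the Ortho Bromine from a Chalcone Scaffold

This account rests on a few compounds, and the source may have more. Where it says the series, first, only, none or still open, it means among the compounds named here.

Compound 1, `O=C(/C=C/c1cccc(OCc2ccccc2)c1)c1ccccc1Br`: 1800 nM
Compound 2, `O=C(/C=C/c1cccc(OCc2ccccc2)c1)c1ccc([N+](=O)[O-])cc1`: 23300 nM

In a functional assay on MDA-MB-231 cells (Homo sapiens) for cytotoxicity, read by MTT assay, with a stated time of 68 h (on this read-out lower numbers stand for stronger inhibition and higher numbers for weaker inhibition), compound 1 stands lowest of the two measured compounds; its nearest neighbour is compound 2, and a 13-fold higher number from compound 1 to compound 2 (1.11 log units; beyond the scatter). Compound 3, `O=C(/C=C/c1cccc(OCc2ccccc2)c1)c1ccccc1`, has not yet been measured. It differs from compound 1 by hydrogen in place of bromo on an aromatic carbon. Within the data shown here, no measured step removes a bromo from this ring; the single known step, from compound 1 to compound 2, swaps the whole 2-bromophenyl for 4-nitrophenyl and so bears only loosely on the change to compound 3. That step was large, which shows that this ring is sensitive to change, but a plain phenyl is a smaller departure than 4-nitrophenyl. A modest loss of potency is therefore expected for compound 3, a 2.1-fold higher number from compound 1 to compound 3 (0.32 log units; beyond the scatter). Compound 3 is estimated at 3800 nM in this assay, within the range 1300 nM to 11000 nM.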

Compound 3, half-maximal inhibitory concentration: 20000 nM
Estimate against measurement, compound 3: 5.3-fold (0.72 log units) below, and the stated range ends below it.
By their numbers in this assay, from the lowest: compound 1; then compounds 3 and 2 (each within the scatter of the next).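

In this assay, the loss of the bromo alone is enough for a large step: an 11-fold higher number from compound 1 to compound 3 (1.05 log units; beyond the scatter). Placing nitro on the plain phenyl ring adds no change beyond the scatter, a 1.2-fold lower number from compound 2 to compound 3 (0.07 log units; within the scatter), so among these compounds the large step from the 2-bromophenyl to the 4-nitrophenyl is matched by removing the bromo, and the nitro itself need not be invoked to account for it. Nothing here explains why this single atom carries so much weight in this assay.

The compounds shown leave open whether the bromo is specifically required or whether another group on the same aromatic carbon, such as chloro, methyl or methoxy, would keep the number of compound 1. They also leave open whether a bromo on another carbon of this ring would do the same.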